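A few compounds are considered here, and "the series" means these few. Any claim that something is new, unique, unknown or untested is made for them only; others in the source may bear on it.

Measured compounds:
compound 1, `CC[C@@H]1C[C@H](CC)CN(CCCNC(=O)C2CCN(Cc3nc(-c4ccccc4C)oc3C)CC2)C1`: 3470 nM
compound 2, `Cc1oc(-c2ccc(Cl)c(Cl)c2)nc1CN1CCC(C(=O)NCCCN2C[C@H](C)C[C@H](C)C2)CC1`: 3170 nM

Both compounds were tested in an ADME assay on Huh7.5.1 cells (Homo sapiens) for cytotoxicity, read by ATP content, with a stated time of 48 h; on this read-out higher numbers stand for lower toxicity in this test and lower numbers for higher toxicity in this test. Compound 1 gives 3470 nM in this assay, and compound 2 gives 3170 nM. Within the data shown here, of the two numbers, the one for compound 2 stands at the bottom, but its gap to compound 1 is within the scatter of repeated measurements, so the two compounds are not distinguished by this read-out.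

Compound 3, `Cc1ccc(-c2nc(CN3CCC(C(=O)NCCCN4C[C@H](C)C[C@H](C)C4)CC3)c(C)o2)c(C)c1`, has not yet been measured in this assay. It differs from compound 2 in one place: 2,4-dimethylphenyl in place of 3,4-dichlorophenyl on an aromatic carbon. Among the measured compounds shown here, nothing in the two measured compounds speaks for or against a change from this exchange, and no step between measured compounds exists to lean on. The step from compound 2 to compound 3 is therefore expected to be a 1.0-fold higher number from compound 2 to compound 3 (0.02 log units; within the scatter), that is, nothing beyond the scatter. Compound 3 is estimated to give 3300 nM in this assay, with a plausible range from 1600 nM to 7000 nM.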

Compound 3, half-maximal cytotoxic concentration: 4110 nM
Compound 3: middle estimate off by 1.2-fold (0.10 log units), on the low side, and the stated range covers the measured number.
By their numbers in this assay, from the lowest: compounds 2, 1 and 3 (each within the scatter of the next).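

In this assay, 2,4-dimethylphenyl in place of 3,4-dichlorophenyl on this aromatic carbon of the five-membered ring gives a 1.3-fold higher number from compound 2 to compound 3 (0.11 log units; within the scatter). This is the only step shown between compounds that differ in one place, and it shows that this position accepts an exchange of the chlorine-bearing ring for a ring of carbon only without a change beyond the scatter. Since the two groups differ both in their atoms and in where these stand on the phenyl ring, the step cannot say which of the two matters, if either does.

On these data alone, whether an amine or a carboxylic acid on the phenyl ring, or a longer chain in place of that ring, would move the number beyond the scatter stays open. The measurements shown also offer no explanation for the size of this step.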